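The source may hold more compounds than are shown below. What is called first, only, known or untested is meant among the compounds shown, and "the series" means these compounds.

Values measured in a functional assay on brain (Rattus norvegicus, strain Wistar) for inhibition; a higher number here means a weaker inhibitor, a lower number a stronger inhibitor:
- Compound 1 `Cc1[nH]c(=O)n(C)c1-c1ccccc1`: > 100000 nM. This is a limit of the assay, not a number.
- Compound 2 `CCCCOc1ccc(-c2c(C)[nH]c(=O)n2C)cc1`: 5100 nM
- Compound 3 `Cc1[nH]c(=O)n(C)c1-c1ccc(OC(C)C)cc1`: 20400 nM

Of the two actual numbers, compound 3 has the higher, and compound 2 is its nearest neighbour, with a 4.0-fold higher number from compound 2 to compound 3 (0.60 log units; beyond the scatter). Compound 4 `CCCCCc1ccc(-c2c(C)[nH]c(=O)n2C)cc1` has pentyl in place of isopropoxy on an aromatic carbon.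

For the measured compounds named here, three measured steps bear on this change. Butoxy in place of hydrogen gave an at least 19-fold lower number from compound 1 to compound 2 (1.29 log units; beyond the scatter), a large step. Isopropoxy in place of hydrogen gave an at least 4.9-fold lower number from compound 1 to compound 3 (0.69 log units; beyond the scatter), a smaller one, though both rest on the limit (the limit of > 100000 nM in this assay, at which 1 of the 3 values shown sits). Between the two substituted compounds, the change in the group on oxygen gave a modest step. Going by the values given here, no compound with a carbon chain directly on the ring has been measured, so the loss of the oxygen remains untested.

Pentyl resembles the butoxy of compound 2 5100 nM more than it resembles isopropoxy, so a modest move towards a lower number is expected in this assay. The expected change is a 3.1-fold lower number from compound 3 to compound 4 (0.50 log units; beyond the scatter). For compound 4 the estimated value is 6500 nM, with an expected range of 1800 nM to 25000 nM.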

Compound 4, half-maximal inhibitory concentration: 5900 nM
For compound 4 the middle estimate is 1.1-fold (0.04 log units) above the measured one; the range from low to high includes it.
By their numbers in this assay, from the lowest: compounds 2 and 4 (each within the scatter of the next); then compound 3. At a limit, above all of these: compound 1.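

In this assay, the oxygen on the aromatic carbon turns out not to be required: pentyl, which brings no hydrogen-bond acceptor, in place of butoxy gave a 1.2-fold higher number from compound 2 to compound 4 (0.06 log units; within the scatter), so these two groups cannot be told apart here. Pentyl in place of isopropoxy gave a 3.5-fold lower number from compound 3 to compound 4 (0.54 log units; beyond the scatter), which places compound 3 apart from the two compounds with unbranched chains, and shows that the earlier gap between butoxy and isopropoxy does not depend on the oxygen being kept. The step from the unsubstituted compound, an at least 16-fold lower number from compound 1 to compound 4 (1.22 log units; beyond the scatter), confirms that a group at this position matters, but it gives only a minimum size, as it rests on a limit: the limit of > 100000 nM in this assay, at which 1 of the 4 values shown sits.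

Isopropoxy differs from the two unbranched chains in both length and branching, so a propoxy group would be needed to separate these two features, and the compounds shown cannot say which of them accounts for the gap. Going by these compounds, how a longer chain such as octyl would behave on this aromatic carbon remains open, as does the effect of an amine or a carboxylic acid at the end of the chain.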